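A few compounds are considered here, and "the series" means these few. Any claim that something is new, unique, unknown or untested is made for them only; others in the source may bear on it.

In a functional assay on HeLa cells (Homo sapiens) for antiproliferative activity, read by MTT assay, with a stated time of 72 h (a lower number here means a stronger inhibitor, a higher number a weaker inhibitor), compound 1 `O=C1O/C(=C\Cn2cnc3cncc(Br)c32)C(OCc2ccccc2)=C1OCc1ccccc1` gives 15000 nM, compound 2 `O=C1NC(O)(CCn2cnc3ccn(CCC4(O)NC(=O)C(OCc5ccccc5)=C4OCc4ccccc4)c3c2=O)C(OCc2ccccc2)=C1OCc1ccccc1` gives 17000 nM; 18000 nM (2 entries), and compound 3 `O=C1NC(O)(CCn2cnc3ccnc(Cl)c32)C(OCc2ccccc2)=C1OCc1ccccc1` gives 21000 nM. Compound 1 and compound 3 lie within the usual scatter of each other, so compound 1 has no clear edge over its nearest neighbour. Compound 4 `O=C1O/C(=C\Cn2cnc3c(Cl)c(F)nc(F)c32)C(OCc2ccccc2)=C1OCc1ccccc1` departs from compound 1 on a saturated chain carbon bound to a double-bonded chain carbon: a group of 12 heavy atoms (6 carbon, 3 nitrogen, 2 fluorine, 1 chlorine; one five-membered aromatic ring with 2 hetero atoms, one six-membered aromatic ring with 1 hetero atom) in place of a group of 10 heavy atoms (6 carbon, 3 nitrogen, 1 bromine; one five-membered aromatic ring with 2 hetero atoms, one six-membered aromatic ring with 1 hetero atom), on a saturated chain carbon bound to a double-bonded chain carbon. Going by the values given here, no measured pair in this set isolates such a change, so no step beyond the scatter is expected in this assay, and the starting point is compound 1 at 15000 nM. The expected 1.3-fold lower number from compound 1 to compound 4 (0.10 log units; within the scatter) is therefore small. For compound 4 the estimated value is 12000 nM, with an expected range of 4000 nM to 35000 nM.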

Compound 4, half-maximal inhibitory concentration: > 100000 nM
Compound 4 ended at the assay's limit; the forecaster's own chance of this, stated with the estimate: 10%; middle value at least 8.3-fold (0.92 log units) from the limit.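

Putting the group of 12 heavy atoms, with its two fluorine atoms and one chlorine, in place of the bromine-bearing group of 10 heavy atoms gives an at least 6.6-fold higher number from compound 1 to compound 4 (0.82 log units; beyond the scatter) in this assay. Going by these compounds alone, this is the first step at this place on a saturated chain carbon bound to a double-bonded chain carbon, and it shows that the read-out responds to the change of group there. Compound 4 stands at a limit of the assay, not at a number: the limit of > 100000 nM in this assay, at which 1 of the 4 values shown sits.

The fluorine atoms, the chlorine and the loss of bromine change together, so the compounds shown do not separate them. They also leave open how an amine or a carboxylic acid in place of the bromine would read.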